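The compounds below may be only part of what the source reports. "The series", "measured", "known", "first", "only" and "open" are said of these compounds alone.

Compound 1 `O=C1OCC=C1CSC(=S)NC1CC1`, compound 2 `CNC(=S)SCC1=CCOC1=O` and compound 3 `CC(C)NC(=S)SCC1=CCOC1=O` share one core and differ only in the group carried on an amide-type nitrogen. In a functional assay on PC-3 cells (Homo sapiens) for antiproliferative activity, read by MTT assay, with a stated time of 72 h (on this read-out lower numbers stand for stronger inhibition and higher numbers for weaker inhibition), compound 1 gives 117000 nM, compound 2 gives 76500 nM, and compound 3 gives 49400 nM. The step of a 2.4-fold lower number from compound 1 to compound 3 (0.37 log units; beyond the scatter) is the only one beyond the scatter; the steps of a 1.5-fold lower number from compound 1 to compound 2 (0.18 log units; within the scatter) and a 1.5-fold lower number from compound 2 to compound 3 (0.19 log units; within the scatter) both stay within it. Compound 3 and compound 2 therefore give numbers that cannot be told apart, and only compound 1 lies clearly apart from compound 3.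

Compound 4 `O=C1OCC=C1CSC(=S)N1CCCC1` is the next step: pyrrolidin-1-yl in place of isopropylamino on a thiocarbonyl carbon. The measured steps all swap one open chain for another on that nitrogen, whereas the change to compound 4 closes the nitrogen into a ring and removes the hydrogen-bond donor. The three known steps bear on it only loosely: the largest, a 2.4-fold lower number from compound 1 to compound 3 (0.37 log units; beyond the scatter), was modest, and the others were within the scatter. The change is therefore expected to leave the number near where compound 3 stands, a 1.1-fold lower number from compound 3 to compound 4 (0.04 log units; within the scatter). Compound 4 is expected to give about 45000 nM, within a range from 18000 nM to 110000 nM.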

Compound 4, half-maximal inhibitory concentration: 114000 nM
Compound 4: middle estimate off by 2.5-fold (0.40 log units), on the low side; measured number above the stated range.
By their numbers in this assay, from the lowest: compounds 3, 2, 4 and 1 (each within the scatter of the next, the first and the last beyond it).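

Pyrrolidin-1-yl is the first group here that closes the nitrogen into a ring and leaves it without a hydrogen-bond donor, and in this assay this change gives a 2.3-fold higher number from compound 3 to compound 4 (0.36 log units; beyond the scatter). Against the other two groups the result stays within the scatter (a 1.5-fold higher number from compound 2 to compound 4 (0.17 log units; within the scatter)) and (a 1.0-fold lower number from compound 1 to compound 4 (0.01 log units; within the scatter)), so this position does not simply reward the new ring or penalize it: the outcome depends on which group it is compared with. No measurement shown here explains the step from isopropylamino to pyrrolidin-1-yl.

The ring closure and the loss of the donor arrive together in compound 4, so the compounds shown cannot separate them. Dimethylamino, an open group also without that donor, and piperidin-1-yl, a larger ring, remain open comparisons at this position.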